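The source may hold more compounds than are shown below. What is called first, only, known or untested is meant among the compounds shown, and "the series" means these compounds.

Measured in a functional assay on MDA-MB-231 cells (Homo sapiens) for inhibition, read by MTT assay, with a stated time of 48 h; on this read-out higher numbers stand for weaker inhibition of growth and lower numbers for stronger inhibition of growth:

Compound 1 `Oc1cccc(Nc2ncnc3ccc(NC(=S)NCc4ccccc4)cc23)c1`: > 30000 nM, which is a limit of the assay
Compound 2 `Oc1ccc(Nc2ncnc3ccc(NC(=S)NCc4ccccc4)cc23)cc1`: 27000 nM
Compound 3 `FC(F)(F)c1cc(NC(=S)Nc2ccc3ncnc(Nc4cccc(Br)c4)c3c2)ccc1Cl`: 1100 nM

Of the two actual numbers in this assay, compound 3 has the lower, at 1100 nM. The number for compound 2, at 27000 nM, lies higher, and that gap is beyond the scatter.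

Compound 4 `S=C(Nc1ccc(Cl)c(Cl)c1)Nc1ccc2ncnc(Nc3cccc(Br)c3)c2c1` departs from compound 3 in one place: chloro in place of trifluoromethyl on an aromatic carbon. Put another way, 4-chloro-3-(trifluoromethyl)phenyl becomes 3,4-dichlorophenyl.

Among the measured compounds shown here, only one single-place step has been measured, an at least 1.1-fold lower number from compound 1 to compound 2 (0.04 log units; that floor lies within the scatter). It exchanges 3-hydroxyphenyl for 4-hydroxyphenyl, a different change from the one at issue here, and it starts from a limit. For the measured compounds named here, it therefore gives no direct measure for replacing trifluoromethyl with chloro, and no measured step sets a direction for that change.

With no such evidence, compound 4 is expected to stay close to compound 3 at 1100 nM. The expected change is a 1.2-fold higher number from compound 3 to compound 4 (0.07 log units; within the scatter), with no shift beyond the scatter anticipated. For compound 4 the estimated value is 1300 nM, with an expected range from 450 nM to 4000 nM.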

Compound 4, concentration for 50% growth inhibition: 4800 nM
Compound 4: the middle estimate sits 3.7-fold (0.57 log units) below what was measured; the measured number lies above the stated range.
By their numbers in this assay, from the lowest: compound 3; then compound 4; then compound 2. At a limit, above all of these: compound 1.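

In this assay, the aromatic carbon ortho to a chloro group and meta to a large group proves sensitive to this exchange: a 4.4-fold higher number from compound 3 to compound 4 (0.64 log units; beyond the scatter). The only earlier step, 4-hydroxyphenyl in place of 3-hydroxyphenyl, started from a limit and its floor stayed within the scatter, so this is the first single-place step shown with a firm direction, and it favours 4-chloro-3-(trifluoromethyl)phenyl over 3,4-dichlorophenyl. Nothing measured here accounts for the shift.

From the compounds shown here alone, whether a methyl, a methoxy or a nitrile on this carbon would fall nearer compound 3 or nearer compound 4 stays open, as does how an amine or a carboxylic acid there would read out. Going by these compounds, it also stays open whether the same exchange would give a step of like size with the hydroxyphenyl groups of compound 1 and compound 2 on the shared core, in place of the group that compound 3 carries there.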